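A cycloheptyl amide against the assay limit

The source may hold more compounds than are shown below. What is called first, only, known or untested is meant among the compounds shown, and "the series" means these compounds.

In an ADME assay on MRC5 cells (Homo sapiens) for inhibition, with a stated time of 72 h (a lower number here means that less compound is needed, a higher number that more compound is needed for the effect), compound 1 (`COc1cccc(OC)c1C(=O)Nc1c[nH]nc1C(=O)NC1CC1`) gives > 50000 nM as a limit of the assay and not a number. Compound 2 (`COc1cccc(OC)c1C(=O)Nc1c[nH]nc1C(=O)NCc1ccccc1`) gives 50000 nM as a measured number. Compound 3 (`COc1cccc(OC)c1C(=O)Nc1c[nH]nc1C(=O)NCCN1CCCC1`) gives > 50000 nM and so stands, like compound 1, at a limit only. That leaves the limit of > 50000 nM in this assay, at which 2 of the 3 values shown sit, as the frame for what follows.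

Compound 4 (`COc1cccc(OC)c1C(=O)Nc1c[nH]nc1C(=O)NC1CCCCCC1`) has cycloheptyl in place of 2-(pyrrolidin-1-yl)ethyl on an amide-type nitrogen. Three measured steps change this same substituent: a number no higher from compound 1 to compound 2 (the limit leaves the size open) and a step that the two limits leave unreadable from compound 1 to compound 3 and a number no lower from compound 2 to compound 3 (the limit leaves the size open) all leave their size unreadable. Among the compounds with values here, with no readable size to carry over, only a small move towards a lower number is expected, resting on compound 2 at 50000 nM as the one number available. The expected step runs an at least 1.2-fold lower number from compound 3 to compound 4 (0.09 log units; that floor lies within the scatter) in this assay with a real chance of another limit. For compound 4 the estimated value is 40000 nM with an expected range of 15000 nM to 60000 nM in this reading.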

Compound 4, half-maximal effective concentration: 42000 nM
Compound 4: middle estimate off by 1.1-fold (0.02 log units), on the low side; measured number inside the range.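

In this assay, cycloheptyl on the amide-type nitrogen supplies a second measured number alongside the one for benzyl, so these two groups can now be compared directly: the change reads as a 1.2-fold lower number from compound 2 to compound 4 (0.08 log units; within the scatter). Against the two compounds held at a limit, the steps read as an at least 1.1-fold lower number from compound 3 to compound 4 (0.07 log units; that floor lies within the scatter) and as an at least 1.1-fold lower number from compound 1 to compound 4 (0.07 log units; that floor lies within the scatter), so the change from 2-(pyrrolidin-1-yl)ethyl or cyclopropyl to cycloheptyl now has a readable floor, though neither floor clears the scatter. The whole set still stays close to the limit of the assay: the limit of > 50000 nM in this assay, at which 2 of the 4 values shown sit.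

The compounds shown leave open whether a carboxylic acid or a longer alkyl chain on this amide-type nitrogen would move the number beyond the scatter. They also leave open whether a change elsewhere on the shared core would do so.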